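A few compounds are considered here, and "the series" means these few. Any claim that something is new, unique, unknown or untested is made for them only; others in the source may bear on it.

In a functional assay on SK-OV-3 cells (Homo sapiens) for cytotoxicity (on this read-out lower numbers stand for stronger inhibition of growth and higher numbers for weaker inhibition of growth), compound 3 `COc1ccc(C2=C(c3ccc(SC)cc3)CC3CCCN3C2=O)cc1` gives 3000 nM, the lowest number among the three measured compounds. Compound 2 `COc1ccc(C2=C(c3ccc(SC)cc3)CC3CCCN3C2=O)cc1C` gives 15000 nM, and the change of methyl to hydrogen on an aromatic carbon gives a 5.0-fold lower number from compound 2 to compound 3 (0.70 log units; beyond the scatter). Compound 1 `COc1ccc(C2=C(c3ccc(SC)cc3)CC3CCCN3C2=O)cc1O` gives > 100000 nM, which is a limit of the assay.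

Compound 4 `CSc1ccc(C2=C(c3ccc(O)cc3)C(=O)N3CCCC3C2)cc1` has not yet been measured. Its structure departs from that of compound 3 as follows: hydrogen in place of methyl on an oxygen on an aromatic ring. This is hydrogen in place of methyl on an oxygen on an aromatic ring, so that 4-methoxyphenyl becomes 4-hydroxyphenyl. Among the compounds with values here, no measured step makes this same change, so the evidence is indirect. The nearest steps start from the hydroxy group of compound 1, at a different place on the compounds. Hydrogen in place of that hydroxy gives an at least 33-fold lower number from compound 1 to compound 3 (1.52 log units; beyond the scatter), a large step, and methyl in place of it gives an at least 6.6-fold lower number from compound 1 to compound 2 (0.82 log units; beyond the scatter). Both steps link a free hydroxy with a higher number, so a modest step toward weaker growth inhibition is expected, though with wide uncertainty. The expected change is a 4.0-fold higher number from compound 3 to compound 4 (0.60 log units; beyond the scatter). For compound 4 the estimated value is 12000 nM, with an expected range from 3000 nM to 60000 nM.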

Compound 4, concentration for 50% growth inhibition: > 100000 nM
Compound 4: only a limit was reported (the forecaster's own chance of this, stated with the estimate: 20%); middle value at least 8.3-fold (0.92 log units) away from the limit.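

The earlier compounds shown here tied a free hydroxy to a loss of growth inhibition only at the other place on the ring, while here the methoxy oxygen itself is tested: in this assay, hydrogen in place of methyl on this oxygen gives an at least 33-fold higher number from compound 3 to compound 4 (1.52 log units; beyond the scatter), a large step that shows the methyl on this oxygen matters to compound 3. The same 4-hydroxyphenyl group also falls behind the 4-methoxy-3-methylphenyl group, with an at least 6.6-fold higher number from compound 2 to compound 4 (0.82 log units; beyond the scatter), so compound 4 stands clearly behind both measured compounds that carry no free hydroxy. Among the four compounds shown, each of the two with a free hydroxy, compound 1 and compound 4, ends at the same limit, which is a limit and not a number: the limit of > 100000 nM in this assay, at which 2 of the 4 values shown sit.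

From the compounds shown here alone, the step between compound 1 and compound 4 cannot be read, so the two hydroxy compounds cannot be ranked and the full size of the loss at either place stays unknown. Going by these compounds, whether an ethoxy group, a longer chain on this oxygen or an amine in its place would keep the growth inhibition of compound 3 also remains open.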